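Carbamate-to-aryl amide swap on the piperidine nitrogen

This account rests on a few compounds, and the source may have more. Where it says the series, first, only, none or still open, it means among the compounds named here.

Measured so far:
Compound 1 `Cc1nc(S(C)(=O)=O)ccc1Oc1ncnc(OC2CCN(C(=O)OC3(C(F)(F)F)CCC3)CC2)c1F`: 14.3 nM
Compound 2 `Cc1nc(S(C)(=O)=O)ccc1Oc1ncnc(OC2CCN(C(=S)OC(C)C)CC2)c1F`: 69.9 nM

In a functional assay on isolated protein for inhibition of Glucose-dependent insulinotropic receptor (Homo sapiens), read by HTRF and cAMP accumulation (a higher number here means that more compound is needed for the effect, a lower number that less compound is needed), compound 1 gives the lowest of the two numbers; compound 2 lies at a 4.9-fold higher number from compound 1 to compound 2 (0.69 log units; beyond the scatter). The unmeasured compound 3 `Cc1nc(S(C)(=O)=O)ccc1Oc1ncnc(OC2CCN(C(=O)c3ncc(Cl)cn3)CC2)c1F` keeps the shared core of compound 1 and changes only the group on the carbonyl carbon: a group of 7 heavy atoms (4 carbon, 2 nitrogen, 1 chlorine; one six-membered aromatic ring with 2 hetero atoms) in place of a group of 9 heavy atoms (5 carbon, 1 oxygen, 3 fluorine; one four-membered non-aromatic ring of carbon only), on a carbonyl carbon. Within the data shown here, the one step available, a 4.9-fold higher number from compound 1 to compound 2 (0.69 log units; beyond the scatter), touches the same region but replaces the whole carbamate, not only the group on the carbonyl carbon, so it bears on compound 3 only loosely. It shows that a change at this position can move this assay by a modest amount. Compound 3 is therefore expected to land near compound 1 with a small loss, a 2.1-fold higher number from compound 1 to compound 3 (0.32 log units; beyond the scatter), giving an estimated 30 nM with a range from 8 nM to 120 nM.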

Compound 3, half-maximal effective concentration: 6.12 nM
The estimate for compound 3 lay 4.9-fold (0.69 log units) above the measured number, and the stated range ends above it.
By their numbers in this assay, from the lowest: compound 3; then compound 1; then compound 2.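

In this assay, the group on the carbonyl carbon need not be an alkoxy group of the carbamate type: 5-chloropyrimidin-2-yl in place of the group with the four-membered carbon ring gives a 2.3-fold lower number from compound 1 to compound 3 (0.37 log units; beyond the scatter). The change on the amine nitrogen in a ring now spans more range than the earlier pair showed, with an 11-fold lower number from compound 2 to compound 3 (1.06 log units; beyond the scatter), although that step replaces the whole group and cannot be assigned to any single part of it. Nothing at hand accounts for either step.

Open, going by these compounds, is how much of the gain rests on the chlorine and how much on the ring nitrogens. An unsubstituted pyrimidin-2-yl or a chlorophenyl group on the same carbonyl carbon would separate the two.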